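The source may report more compounds than this note shows. Statements on the series, on what has been measured and on what is new or still open speak of the compounds shown alone.

Measured compounds in a functional assay on MGC-803 cells (Homo sapiens) for antiproliferative activity, read by MTT assay, with a stated time of 72 h; on this read-out lower numbers stand for stronger inhibition and higher numbers for weaker inhibition:
- compound 1 `CCCSc1nc(N/N=C(\C)c2ccccc2O)c2nnn(Cc3ccco3)c2n1` gives 4760 nM
- compound 2 `CCCSc1nc(N/N=C/c2cccnc2)c2nnn(Cc3ccccc3)c2n1` gives 38100 nM
- compound 3 `CCCSc1nc(N/N=C/c2cccc(Cl)c2)c2nnn(Cc3ccccc3)c2n1` reaches only > 64000 nM, which is a limit of the assay and not a number.

Compound 1 stands lowest of the two numbers; compound 2 lies higher, and that gap is beyond the scatter. Compound 3 sits at the limit of > 64000 nM in this assay, at which 1 of the 3 values shown sits. For the measured compounds named here, the one measured step, an at least 1.6-fold higher number from compound 2 to compound 3 (0.22 log units; that floor lies within the scatter), changes the group on the carbon with a double bond to nitrogen and leaves the rest of the shared core untouched.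

Compound 4 `CCCSc1nc(N/N=C(\C)c2ccccc2O)c2nnn(Cc3ccc(F)cc3)c2n1` differs from compound 1 at another place: 4-fluorophenyl in place of furan-2-yl on a saturated chain carbon bound to an aromatic nitrogen. No measured step touches the group on the saturated chain carbon bound to an aromatic nitrogen, so no step bears directly on this change, and nothing shown points to a shift in either direction beyond the scatter. Compound 4 is therefore expected to stay close to compound 1, a step of a 1.1-fold higher number from compound 1 to compound 4 (0.02 log units; within the scatter). The estimate for compound 4 in this assay is 5000 nM, with a range from 1500 nM to 16000 nM.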

Compound 4, half-maximal inhibitory concentration: 11000 nM
Estimate against measurement, compound 4: 2.2-fold (0.34 log units) below; the measured number falls inside the stated range.
By their numbers in this assay, from the lowest: compound 1; then compound 4; then compound 2. At a limit, above all of these: compound 3.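

In this assay, replacing furan-2-yl with 4-fluorophenyl on a saturated chain carbon bound to an aromatic nitrogen gives a 2.3-fold higher number from compound 1 to compound 4 (0.36 log units; beyond the scatter), so the number does respond to the group at this place. For the compounds shown here, the only earlier step changed the group on a carbon with a double bond to nitrogen and could say nothing about this second place, where the shift is modest but exceeds the usual scatter. Nothing measured here accounts for the direction or size of this step.

One swap cannot separate the effect of the fluorine from that of exchanging a five-membered aromatic ring for a six-membered one. Going by these compounds, it also remains open how a thiophen-2-yl, a 4-methoxyphenyl or a cyclohexyl group at this place would compare with furan-2-yl and 4-fluorophenyl.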